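Swapping an aliphatic amide for an aromatic one

The compounds below may be only part of what the source reports. "The series", "measured", "known", "first", "only" and "open" are said of these compounds alone.

Three compounds from a common core have been examined in an ADME assay on HepG2 2.2.15 cells (Homo sapiens) for cytotoxicity; on this read-out lower numbers stand for higher toxicity in this test and higher numbers for lower toxicity in this test. Compound 1 `Clc1ccc(C(Oc2ccc3cc(Br)ccc3c2)c2cnc(NCC3CCOCC3)s2)cc1` carries an amine-linked side chain and compound 2 `O=C(Nc1ncc(C(Oc2ccc3cc(Br)ccc3c2)c2ccc(Cl)cc2)s1)C1CC1` a cyclopropyl amide, and in this assay compound 1 gives "not toxic" (no number reported) while compound 2 gives "not toxic" (no number reported). Compound 3 `CCCCCC(=O)Nc1ncc(C(Oc2ccc3cc(Br)ccc3c2)c2ccc(Cl)cc2)s1` carries a hexanoyl amide. For compound 3 the result in this assay is a limit of the assay, > 50000 nM, and no single number is available. Among the three values, compound 3 alone sits at the limit of > 50000 nM in this assay, at which 1 of the 3 values shown sits, and the other two entries carry no number at all, so no step between measured compounds can be computed.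

Compound 4 `O=C(Nc1ncc(C(Oc2ccc3cc(Br)ccc3c2)c2ccc(Cl)cc2)s1)c1ccc(F)cc1` differs from compound 3 in one place: 4-fluorophenyl in place of pentyl on a carbonyl carbon. Since every measured member of this series has come through this assay without a recorded cytotoxic concentration, the step from compound 3 to compound 4 is expected to stay within the scatter, a number no higher from compound 3 to compound 4 (the limit leaves the size open), with no direction favoured. The estimate for compound 4 in this assay is therefore 50000 nM, with a range from 20000 nM to 120000 nM, and it is expected that the assay again reports only a limit rather than a number.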

Compound 4, half-maximal cytotoxic concentration: "not toxic" (no number reported)
Nothing numeric was reported for compound 4, so the estimate cannot be set against anything.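

Among these compounds, compound 4 gives "not toxic" (no number reported) in this assay, with no number to set against the result for compound 3, so no step between compound 3 and compound 4 can be read. The compounds shown leave open at what concentration, if any, they become cytotoxic, and whether 4-fluorophenyl in place of pentyl shifts that concentration.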